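A few compounds are considered here, and "the series" means these few. Any claim that something is new, unique, unknown or untested is made for them only; others in the source may bear on it.

Series in a functional assay on L5178Y cells (Mus musculus) for inhibition, read by MTT assay, with a stated time of 24 h; on this read-out lower numbers stand for stronger inhibition and higher numbers for weaker inhibition:
compound 1 `COc1cc(O)c2c(c1)O[C@H](c1ccc(O)cc1)C/C2=N\NC(=O)Cc1c[nH]c2ccccc12`: >= 11300 nM (a limit)
compound 2 `COc1ccc([C@@H]2C/C(=N\NC(=O)c3ccc(N)cc3)c3c(O)cc(OC)cc3O2)cc1`: 3900 nM
compound 3 `COc1ccc([C@@H]2C/C(=N\NC(=O)c3ccco3)c3c(O)cc(OC)cc3O2)cc1`: 2700 nM

Compound 3, at 2700 nM, lies within the scatter of compound 2, at 3900 nM. Among the measured compounds shown here, these are the only two true numbers so far.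

Next is compound 4 `COc1ccc([C@@H]2C/C(=N\NC(=O)Cc3c[nH]c4ccccc34)c3c(O)cc(OC)cc3O2)cc1`, which differs from compound 3 by (1H-indol-3-yl)methyl in place of furan-2-yl on a carbonyl carbon. For the measured compounds named here, the only measured step at that carbonyl carbon is a 1.4-fold lower number from compound 2 to compound 3 (0.16 log units; within the scatter), so swapping one group there has not yet moved the number beyond the scatter.

Going by the values given here, the only measured compound with (1H-indol-3-yl)methyl on that carbonyl carbon is compound 1, which reports >= 11300 nM, a limit and not a number. On that single reading, a modest move towards higher numbers is expected in this assay, with little certainty. The expected change is a 2.2-fold higher number from compound 3 to compound 4 (0.35 log units; beyond the scatter). For compound 4 the estimated value is 6000 nM, with an expected range of 2500 nM to 16000 nM.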

Compound 4, half-maximal inhibitory concentration: 8600 nM
For compound 4 the middle estimate is 1.4-fold (0.16 log units) below the measured one, and the stated range covers the measured number.
By their numbers in this assay, from the lowest: compounds 3 and 2 (each within the scatter of the next); then compound 4. At a limit, above all of these: compound 1.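

Among the compounds shown here, at the carbonyl carbon, (1H-indol-3-yl)methyl gives the first changes beyond the scatter in this assay: a 3.2-fold higher number from compound 3 to compound 4 (0.50 log units; beyond the scatter), and a 2.2-fold higher number from compound 2 to compound 4 (0.34 log units; beyond the scatter). This position therefore responds to the group placed on it, with weaker inhibition for (1H-indol-3-yl)methyl than for furan-2-yl or 4-aminophenyl, although the claim rests on these three compounds alone and the steps are modest. Compound 1 is a limit and not a number, so methyl in place of hydrogen on an oxygen on an aromatic ring reads only as an at least 1.3-fold lower number from compound 1 to compound 4 (0.11 log units; that floor lies within the scatter): the limit of >= 11300 nM in this assay, at which 1 of the 4 values shown sits.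

Still open, as far as these compounds go, is whether the shift follows the indole or its methyl link, which 1H-indol-3-yl or benzyl on the carbonyl carbon would separate. Also open, from the compounds shown here alone, is how a carboxylic acid or an aliphatic amine would read at that carbon.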